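The source may report more compounds than this note shows. Statements on the series, on what has been measured and on what is new or still open speak of the compounds shown alone.

Measured so far in a functional assay on Jurkat cells (Homo sapiens) for inhibition; on this read-out lower numbers stand for stronger inhibition and higher numbers for weaker inhibition:
- compound 1, `CC(C)[C@H](NC(=O)COc1cccc2ccccc12)C(=O)N[C@@H](CC(=O)O)C(=O)CSc1nc(-c2ccccc2)no1`: 102000 nM
- compound 2, `CC(C)[C@H](NC(=O)COc1cccc2ccccc12)C(=O)N[C@@H](CC(=O)O)C(=O)CSc1nc[nH]n1`: for compound 2 only a limit of the assay was recorded, > 200000 nM
- compound 3, `Cc1nnc(SCC(=O)[C@H](CC(=O)O)NC(=O)[C@@H](NC(=O)COc2cccc3ccccc23)C(C)C)s1`: 190000 nM

All three share one core and differ only in the small aromatic ring attached to the sulfur. Compound 3 gives the higher of the two real numbers, yet the gap to compound 1 is small: a 1.9-fold higher number from compound 1 to compound 3 (0.27 log units; within the scatter). The comparison with compound 2 rests on the limit (the limit of > 200000 nM in this assay, at which 1 of the 3 values shown sits), so it reads as an at least 1.0-fold lower number from compound 2 to compound 3 (0.02 log units; that floor lies within the scatter) and tells little.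

Compound 4, `CC(C)[C@H](NC(=O)COc1cccc2ccccc12)C(=O)N[C@@H](CC(=O)O)C(=O)CSc1nnnn1C`, is the next ring swap on that sulfur: 1-methyl-1H-tetrazol-5-yl in place of 5-methyl-1,3,4-thiadiazol-2-yl on a sulfur. Every exchange of this ring seen so far has moved this assay within the scatter, and compound 2 may sit beyond its limit. For compound 4 no step beyond the scatter is therefore expected, no change at the digits printed from compound 3 to compound 4 (within the scatter). The estimate for compound 4 is 190000 nM, with a range from 90000 nM to 400000 nM.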

Compound 4, half-maximal inhibitory concentration: > 200000 nM
Compound 4: no number, only a limit; the forecaster's own chance of this, stated with the estimate: 45%; at least 1.0-fold (0.02 log units) between middle value and limit.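

In this assay compound 4 gives only a limit of the assay, > 200000 nM, and so becomes the second compound in this small set to end at that limit instead of a number: the limit of > 200000 nM in this assay, at which 2 of the 4 values shown sit.

The readable comparisons are an at least 1.0-fold higher number from compound 3 to compound 4 (0.02 log units; that floor lies within the scatter) and an at least 1.9-fold higher number from compound 1 to compound 4 (0.29 log units; that floor lies within the scatter), so 1-methyl-1H-tetrazol-5-yl on this sulfur adds a fourth ring with no readable step beyond the scatter, and the step between the two compounds at the limit cannot be read.

Going by these compounds, how far compound 2 and compound 4 truly lie from the two compounds with real numbers stays open. Also open, on these data alone, is whether an amine or a longer chain in place of the ring on the sulfur would give a number clearly lower than any seen here.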